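A few compounds are considered here, and "the series" means these few. Any claim that something is new, unique, unknown or untested is made for them only; others in the source may bear on it.

In a functional assay on the whole organism with Rattus norvegicus as the target (a higher number here means that more compound is needed for the effect, a lower number that less compound is needed), compound 1 `COCCOC1CCN(c2ccc(-c3cc(-c4cccc(Br)c4)c4c(N)ncnc4n3)nn2)CC1` gives 3 umol/kg, the lowest of the two numbers in hand, and compound 2 `Nc1ncnc2nc(-c3ccc(N4CCC(COC5CCOCC5)CC4)nn3)cc(-c3cccc(Br)c3)c12` gives 5 umol/kg; the step of a 1.7-fold higher number from compound 1 to compound 2 (0.22 log units; within the scatter) shows that exchanging one tail on the saturated ring for another left the read-out essentially unchanged. Compound 3 `CCO[C@H]1CN(c2ccc(-c3cc(-c4cccc(Br)c4)c4c(N)ncnc4n3)nn2)C[C@H]1OCC` is built from the same atoms as compound 1, joined differently: 3,4-diethoxypyrrolidin-1-yl in place of 4-(2-methoxyethoxy)piperidin-1-yl on an aromatic carbon. For the measured compounds named here, no measured step covers this kind of change, because the only step known, a 1.7-fold higher number from compound 1 to compound 2 (0.22 log units; within the scatter), alters a tail on the saturated ring while keeping that ring, whereas here the ring itself changes from six-membered to five-membered and the tails become two ethoxy groups. Going by the values given here, the one precedent argues that this part of the molecule tolerates variation without moving this assay beyond the scatter, but a reshaped ring is a larger departure, so a shift in either direction is possible. The expectation for compound 3 is therefore a number close to compound 1, with wide uncertainty, as step a 1.7-fold higher number from compound 1 to compound 3 (0.22 log units; within the scatter); compound 3 is estimated at 5 umol/kg, in the range 1.5 umol/kg to 16 umol/kg.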

Compound 3, dose for half-maximal effect: 3 umol/kg
Compound 3: the middle estimate sits 1.7-fold (0.22 log units) above what was measured; low and high end bracket the measured number.
By their numbers in this assay, from the lowest: compounds 1, 3 and 2 (each within the scatter of the next).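

In this assay, putting 3,4-diethoxypyrrolidin-1-yl in place of 4-(2-methoxyethoxy)piperidin-1-yl on the aromatic carbon gives no change at the digits printed from compound 1 to compound 3 (within the scatter), so this swap leaves the read-out where it was. The earlier pair varied only the tail on a six-membered ring that stayed in place, whereas this pair shows that the ring itself can go from six-membered to five-membered, with two ethoxy groups and two defined stereocentres, and the number in this assay still stays within the scatter. Nothing measured alongside these numbers accounts for this tolerance.

The compounds shown carry only ether-bearing saturated rings at this position, so it remains open whether a primary amine or a carboxylic acid on the ring, or a piperazine ring in its place, would keep the number in the same range. Also open, going by these compounds, is whether the opposite arrangement at the two stereocentres of the 3,4-diethoxypyrrolidin-1-yl group would give the same read-out as compound 3 does here.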